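The compounds below may be only part of what the source reports. "The series", "measured", "known", "first", "only" and "open" are said of these compounds alone.

Measured compounds:
- Compound 1, `COc1nc2ccc(Br)cc2cc1C(c1ccccc1)n1cc(-c2ccccc2F)nn1`, gives 13.4% in an ADME assay on PC-3 cells (Homo sapiens) for cytotoxicity, read by sulforhodamine B assay, with a stated time of 48 h, tested at 10 uM; a higher number here means more inhibition at the concentration tested (going by the name of the read-out), a lower number less inhibition.
- Compound 2, `COc1nc2ccc(Br)cc2cc1C(c1ccccc1)n1cc(-c2ccc(OC(F)(F)F)cc2)nn1`, gives 21.6% in this assay.

Within the data shown here, of the two numbers, the one for compound 2 is the higher, but the step of a number 8.2 percentage points higher from compound 1 to compound 2 (within the scatter) stays within the scatter, so the two compounds cannot really be told apart on this evidence. That step is the only measured one, and it swaps one aromatic ring for another on the same position of the shared core.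

Compound 3, `COc1nc2ccc(Br)cc2cc1C(c1ccccc1)n1cc(CCCCCO)nn1`, differs from compound 2 by 5-hydroxypentyl in place of 4-(trifluoromethoxy)phenyl on an aromatic carbon. Here an aromatic ring leaves and a flexible chain carrying a hydroxyl enters, a kind of change for which no measured step exists. Among the measured compounds shown here, the single step in hand, a number 8.2 percentage points higher from compound 1 to compound 2 (within the scatter), was within the scatter, and nothing in the data shows that changes at this position move the read-out beyond the scatter. The expectation is therefore a step of a number 7.6 percentage points lower from compound 2 to compound 3 (within the scatter) in this assay, not beyond the scatter, with the direction uncertain. For compound 3 the estimate in this assay is 14%, with a range from 0% to 30%.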

Compound 3, a percentage reported as inhibition, at one concentration (the size of the read-out at that concentration, not a potency): 12.9%
Beside the measured number, compound 3's estimate is 1.1 percentage points above it; low and high end bracket the measured number.
By their numbers in this assay, from the lowest: compounds 3, 1 and 2 (each within the scatter of the next).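

In this assay, a flexible chain without a ring, 5-hydroxypentyl, takes the place of an aromatic ring on the aromatic carbon of the five-membered ring with 3 nitrogen, giving a number 8.7 percentage points lower from compound 2 to compound 3 (within the scatter) and, against the other aromatic ring, a number 0.5 percentage points lower from compound 1 to compound 3 (within the scatter). Among these compounds, until now only one aromatic ring had been exchanged for another here, so this is the first sign that a much wider change at this position, one that removes the ring and adds a hydrogen-bond donor, still leaves the read-out within the scatter for these three compounds. Nothing measured alongside these numbers offers an explanation for them.

Three compounds cannot show whether any group at this position can move the number beyond the scatter, and an amine, a carboxylic acid or a longer chain ending in a hydroxyl could each test that on the shared core. Because each number comes from a single concentration, these values also leave open how the compounds would compare across a range of concentrations.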